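Changing the sulfur-bound ring of compound 2

A few compounds are considered here, and "the series" means these few. Any claim that something is new, unique, unknown or untested is made for them only; others in the source may bear on it.

For the measured compounds named here, in a functional assay on HCT-116 cells (Homo sapiens) for inhibition, read by CCK-8 assay, with a stated time of 72 h, tested at 8 uM (on this read-out higher numbers stand for more inhibition of growth at the one concentration tested and lower numbers for less inhibition of growth), compound 2 `Nc1ccccc1NC(=O)c1ccc(CSc2cccc(F)c2)cc1` gives 81.4%, the highest of the three numbers measured so far. Compound 1 `COc1ccc(SCc2ccc(/C=C/C(=O)Nc3ccccc3N)cc2)cc1OC` gives 49.5% and compound 3 `Cc1ccc(SCc2ccc(/C=C/C(=O)Nc3ccccc3N)cc2)cc1` gives 4.93%, and both lie well beyond the usual scatter from compound 2.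

The next compound, compound 4 `Nc1ccccc1NC(=O)c1ccc(CSc2ccc(Cl)cc2)cc1`, keeps the rest of compound 2 and alters only the ring held on the sulfur: 4-chlorophenyl in place of 3-fluorophenyl on a sulfur. Put simply, 4-chlorophenyl stands in place of 3-fluorophenyl.

Going by the values given here, only one measured step changes the group at this kind of place, and it is large: a number 44.6 percentage points lower from compound 1 to compound 3 (beyond the scatter). That step involves different groups and a core unlike that of compound 2. It suggests that the group on the sulfur can matter a great deal, but it gives no direct guide to this particular swap. Among the compounds with values here, no measured pair compares these two groups.

Compound 2 already stands high at 81.4%, so a fall seems likelier than a rise, though the size is uncertain. The expected change is a moderate one, a number 19.4 percentage points lower from compound 2 to compound 4 (beyond the scatter). For compound 4 the estimated value is 62%, within an expected range of 30% to 90%.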

Compound 4, percent growth inhibition at one concentration: 76.6%
For compound 4 the middle estimate is 14.6 percentage points below the measured one; low and high end bracket the measured number.
By their numbers in this assay, from the lowest: compound 3; then compound 1; then compounds 4 and 2 (each within the scatter of the next).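

In this assay, for the compounds shown here, the change to 4-chlorophenyl in place of 3-fluorophenyl on a sulfur reads as a number 4.8 percentage points lower from compound 2 to compound 4 (within the scatter) and so does not separate the two rings, which makes this the first measured step at this position on the shared core of compound 2. Going by these compounds alone, the only earlier step at this kind of place reads as a number 44.6 percentage points lower from compound 1 to compound 3 (beyond the scatter) and is large, but it involves other groups on another core, so it does not show that every swap on the sulfur matters to the same degree. Nothing available explains why these two halogen-bearing rings read alike.

From the compounds shown here alone, whether 3,4-dimethoxyphenyl and 4-methylphenyl would differ as sharply on the core of compound 2 stays open, so it is unclear whether the large step belongs to those groups or to their core. Also open, going by these compounds, is how an amine, a carboxylic acid or a longer chain on the ring held by the sulfur would read at this one concentration, and whether the two halogen-bearing rings would still match at other concentrations.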